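Capping a phenol: from compound 1 to compound 3

This account rests on a few compounds, and the source may have more. Where it says the series, first, only, none or still open, it means among the compounds named here.

Compound 1, `O=C(Nc1cccc(-n2cc(-c3ccncc3)c(-c3cc(O)cc(Cl)c3)n2)c1)Nc1ccc(Cl)c(C(F)(F)F)c1`, was tested in a functional assay on A498 cells (Homo sapiens) for inhibition, read by sulforhodamine B assay, with a stated time of 48 h, tested at 100 uM (a lower number here means a stronger effect, a higher number a weaker effect of the compound at the concentration tested), where compound 1 gives -35%. Among the measured compounds shown here, its only companion is compound 2, `O=C(Nc1cccc(-n2cc(-c3ccncc3)c(-c3cc(O)cc(Cl)c3)n2)c1)Nc1ccc(Cl)c(Cl)c1`, which in this assay gives -79%; so compound 1 stands as the higher, and therefore weaker, of the two numbers. For the measured compounds named here, the one step seen so far, a number 44 percentage points lower from compound 1 to compound 2 (beyond the scatter), swaps a chloro for a trifluoromethyl on an aromatic carbon. Compound 3, `COc1cc(Cl)cc(-c2nn(-c3cccc(NC(=O)Nc4ccc(Cl)c(C(F)(F)F)c4)c3)cc2-c2ccncc2)c1`, changes compound 1 elsewhere: methyl in place of hydrogen on an oxygen on an aromatic ring, on an oxygen on an aromatic ring whose other neighbour is an aromatic carbon. No measured step touches this oxygen, so nothing shown here tells how large a move to expect in this assay, or in which direction. The expectation for compound 3 is therefore a number close to that of compound 1, an estimated -30% with a range from -60% to 0%, corresponding to an expected step of a number 5 percentage points higher from compound 1 to compound 3 (within the scatter).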

Compound 3, a percentage reported as activity, at one concentration (the size of the read-out at that concentration, not a potency): -70%
Beside the measured number, compound 3's estimate is 40 percentage points above it, and the stated range ends above it.
By their numbers in this assay, from the lowest: compounds 2 and 3 (each within the scatter of the next); then compound 1.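

In this assay, among the compounds shown here, turning the hydroxy into a methoxy gives a number 35 percentage points lower from compound 1 to compound 3 (beyond the scatter), so the first change at this oxygen already has a large effect, and in the stronger direction. On this scaffold, the hydrogen on that oxygen is therefore not needed for the effect at the tested concentration, and adding one methyl carbon there is tolerated and even favourable. No measurement offered here explains why the number moves.

From the compounds shown here alone, it remains open whether the gain belongs to methyl alone or would persist with a longer chain such as ethoxy, or with an amine in place of the hydroxy. Also open, going by these compounds, is whether the methoxy would have a similar effect on compound 2, which carries chloro in place of trifluoromethyl.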